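A few compounds are considered here, and "the series" means these few. Any claim that something is new, unique, unknown or untested is made for them only; others in the source may bear on it.

Measured compounds in an assay on HL-60 cells for inhibition of glutathione S-transferase P (Homo sapiens), read by spectrophotometry, tested at 5 uM; on this read-out lower numbers stand for less inhibition and higher numbers for more inhibition at the one concentration tested (going by the name of the read-out):
- compound 1 `C=C(CC)C(=O)c1ccc(OCc2nc(-c3ccc([N+](=O)[O-])cc3)cs2)c(C)c1C`: 4.4%
- compound 2 `C=C(CC)C(=O)c1ccc(OCc2nc(-c3ccc(C(F)(F)F)cc3)cs2)c(C)c1C`: 0%
- compound 3 `C=C(C)C(=O)c1ccc(OCc2nc(-c3ccc([N+](=O)[O-])cc3)cs2)cc1Cl`: 86.7%

Compounds 1 and 2 share one core and differ in a single place: trifluoromethyl in place of nitro on an aromatic carbon. In this assay the step from that change is a number 4.4 percentage points lower from compound 1 to compound 2 (within the scatter), so compound 1 and compound 2 give numbers that cannot be told apart on this read-out, both near the bottom of the scale.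

Compound 3 is built on a different core. How its core differs from that of compound 1 is not broken down here. In this assay compound 3 gives 86.7%, the highest number among the three, well beyond the scatter from both compound 1 and compound 2.

Compound 4 `C=C(C)C(=O)c1ccc(OCc2nc(-c3ccc(C(F)(F)F)cc3)cs2)cc1Cl` has not yet been measured. It stands to compound 3 as compound 2 stands to compound 1: trifluoromethyl in place of nitro on an aromatic carbon. The change is the same kind of change, at a place described in the same words, but it is now made on the core of compound 3, where the starting number is high rather than near zero. The only guide to its effect is the earlier pair, in which the step from compound 1 to compound 2 was within the scatter, and that pair started from a number so low that a loss, had there been one, could not have shown. Within the data shown here, the step from compound 3 to compound 4 is therefore expected to be modest, a number 16.7 percentage points lower from compound 3 to compound 4 (beyond the scatter), with a wide margin because the single earlier step of a number 4.4 percentage points lower from compound 1 to compound 2 (within the scatter) started from a floor. Compound 4 is estimated at 70%, with a likely range from 30% to 92%.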

Compound 4, a percentage reported as inhibition, at one concentration (the size of the read-out at that concentration, not a potency): 72.3%
Beside the measured number, compound 4's estimate is 2.3 percentage points below it, within the range that was stated.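

In this assay, putting trifluoromethyl in place of nitro on the core of compound 3 gives a number 14.4 percentage points lower from compound 3 to compound 4 (beyond the scatter), so this change costs only a modest part of the reading on this core, and compound 4 still sits high on the scale. The same change on the two cores gives steps that cannot be told apart: the same change on two cores in this assay, a number 4.4 percentage points lower (within the scatter) from compound 1 to compound 2 and a number 14.4 percentage points lower (beyond the scatter) from compound 3 to compound 4, 10 percentage points apart, within the scatter of two such steps

This agreement is weak support for carrying the change from one core to another, since compound 1 at 4.4% and compound 2 at 0% lie near the bottom of the scale, where a loss would have had little room to show, and two pairs tested at a single concentration say nothing about potency or about how the change behaves on any further core.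

The compounds shown leave open how other groups would read in the same place, para to a large group, for example a nitrile, an amine or a carboxylic acid. They also leave open which feature of the core of compound 3 goes with its high numbers, a question that would need compounds differing from it in one place on that core.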